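Swapping a Pyrrolidine for an Anilino Group

A few compounds are considered here, and "the series" means these few. Any claim that something is new, unique, unknown or untested is made for them only; others in the source may bear on it.

Of the compounds shown here, three have been tested so far in a functional assay on the whole organism with Rattus norvegicus as the target, at a dose of 100 mg/kg; a lower number here means less inhibition, a higher number more inhibition at the dose given (going by the name of the read-out). Compound 1 `O=c1ccc(-c2ccccc2)nn1CCCNC(=S)Nc1ccccc1` gives 12.1%. Compound 2 `C/N=C(/NC#N)NCCCCCCn1nc(-c2ccccc2)ccc1=O` gives 31.7%. Compound 3 `C/N=C(/NC#N)NCCCCn1nc(N2CCCC2)ccc1=O` gives -1%, the lowest of the three numbers: compound 1 stands nearest, with a gap beyond the usual scatter, and compound 2 stands furthest, again beyond the scatter.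

The next compound, compound 4 `C/N=C(/NC#N)NCCCCn1nc(Nc2ccccc2)ccc1=O`, differs from compound 3 in a single place: anilino in place of pyrrolidin-1-yl on an aromatic carbon. Going by the values given here, no measured pair differs in exactly this way, so the size of such a step has not been seen directly. What the numbers do show is that compound 2, which also carries a six-membered aromatic ring of carbon only on the shared core, gives the highest of the three values, whereas compound 3 gives the lowest; compound 2 also has a different chain, so that comparison is not a clean one. The step is expected to be a modest rise, a number 16 percentage points higher from compound 3 to compound 4 (beyond the scatter), probably beyond the scatter but short of compound 2. Compound 4 is therefore estimated to give 15%, within a range from -5% to 35%.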

Compound 4, a percentage reported as inhibition, in the whole organism at one dose (the size of the read-out at that dose, not a potency): 24.4%
For compound 4 the middle estimate is 9.4 percentage points below the measured one; measured number inside the range.
By their numbers in this assay, from the lowest: compound 3; then compound 1; then compounds 4 and 2 (each within the scatter of the next).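

Going by these compounds alone, this pair gives the first clean look at this position: on an aromatic carbon next to the ring nitrogen, with the rest of the molecule unchanged, anilino in place of pyrrolidin-1-yl gives a number 25.4 percentage points higher from compound 3 to compound 4 (beyond the scatter) in this assay. The group at this one place therefore has a clear influence on the read-out at this dose, and compound 3, at -1%, shows that the pyrrolidin-1-yl version leaves almost no inhibition to speak of. The swap changes several things at once, replacing a five-membered non-aromatic ring with a six-membered aromatic ring of carbon only and adding a hydrogen-bond donor, and no information here explains why the number rises.

From the compounds shown here alone, a single pair cannot separate these features, so it remains open whether the linking nitrogen hydrogen or the aromatic ring carries the gain, which N-methylanilino or a cyclohexylamino group at the same place could help to tell apart. Going by these compounds, it is also open how a benzylamino group or a substituted ring, such as 4-chloroanilino, would fare on this same chain.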